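This account rests on a few compounds, and the source may have more. Where it says the series, first, only, none or still open, it means among the compounds named here.

Measured compounds, all in an assay on isolated protein for inhibition of advanced glycosylation end product-specific receptor (Homo sapiens), read by FRET, with stated times of 30 min and 1 h, tested at 4 uM; a lower number here means less inhibition, a higher number more inhibition at the concentration tested (going by the name of the read-out):

compound 1 `Clc1ccc(Oc2ccc3nc(-c4ccc(OC5CCNCC5)cc4)oc3c2)cc1` gives 20.6%
compound 2 `Clc1ccc(Oc2ccc3nc(-c4ccc(OCC5CCNCC5)cc4)oc3c2)cc1` gives "not active" (no number reported)
compound 3 `Clc1ccc(Oc2ccc3nc(-c4ccc(OCCCN5CCCC5)cc4)oc3c2)cc1` gives "not active" (no number reported)

Of the three, only compound 1 has a number in this assay; compound 2 and compound 3 are each reported as not active, with no value attached. Compound 3 therefore stands without a single number, and one further entry, compound 2, is in the same position. Going by the values given here, no step between measured compounds is available, so the three entries can only be read side by side: compound 1 shows modest inhibition, compound 3 none that was reported.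

The next compound, compound 4 `CC(C)(C)c1ccc(Oc2ccc3nc(-c4ccc(OCCCN5CCCC5)cc4)oc3c2)cc1`, is the same as compound 3 apart from one change: tert-butyl in place of chloro on an aromatic carbon. No comparable change is present among the measured compounds, so its effect in this assay cannot be read from a shown step. Starting from a compound reported as not active, the expectation is a change small enough to stay within the scatter in either direction, and most likely compound 4 will again be reported only as not active. If a number is reported, compound 4 is expected to give 8%, within a range of 0% to 22%.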

Compound 4, a percentage reported as inhibition, at one concentration (the size of the read-out at that concentration, not a potency): "not active" (no number reported)
Compound 4: no number reported; no gap can be computed for the estimate.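

Compound 3 and compound 4 are both reported as not active in this assay, so no step can be read from chloro to tert-butyl. No evidence bears on this result. The compounds shown leave open whether this change alters inhibition in a compound with a measurable value.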